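The compounds below may be only part of what the source reports. "The series", "measured", "known", "first", "only" and "open" are said of these compounds alone.

Compound 1 `COc1ccc(OC)c(C(=O)/C=C/c2ccco2)c1` is one of two chalcone-type compounds measured in a functional assay on A549 cells (Homo sapiens) for cytotoxicity, read by MTT assay; a higher number here means a weaker inhibitor, a lower number a stronger inhibitor; in this assay compound 1 gives 27900 nM, the highest of the two numbers, while compound 2 `COc1ccc(OC)c(C(=O)/C=C/c2ccoc2)c1` gives 22100 nM. Within the data shown here, the one measured step, a 1.3-fold lower number from compound 1 to compound 2 (0.10 log units; within the scatter), is the only guide to how the ring on the chain may be swapped. Compound 3 `COc1ccc(OC)c(C(=O)/C=C/c2ccc(C)s2)c1` is not yet measured; it differs from compound 1 by 5-methylthiophen-2-yl in place of furan-2-yl on a double-bonded chain carbon bound to a double-bonded chain carbon. Among the measured compounds shown here, no measured step covers this exact exchange of a furan-2-yl for a 5-methylthiophen-2-yl, and the one related step between compound 1 and compound 2 lies within the scatter. The step of a 1.1-fold lower number from compound 1 to compound 3 (0.05 log units; within the scatter) is therefore expected to be small, with no clear direction beyond the scatter. For compound 3 the expected value in this assay is 25000 nM, within a range of 8000 nM to 70000 nM.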

Compound 3, half-maximal inhibitory concentration: 4500 nM
Beside the measured number, compound 3's estimate is 5.6-fold (0.74 log units) above it, and the stated range ends above it.
By their numbers in this assay, from the lowest: compound 3; then compounds 2 and 1 (each within the scatter of the next).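

The ring on the double-bonded chain carbon proves responsive in this assay once more than the furan attachment is altered: the exchange of furan-2-yl for furan-3-yl stayed within the scatter, whereas 5-methylthiophen-2-yl brings a 6.2-fold lower number from compound 1 to compound 3 (0.79 log units; beyond the scatter) and a 4.9-fold lower number from compound 2 to compound 3 (0.69 log units; beyond the scatter) at the same place. Compound 3 therefore has the lowest number of the three, with its steps to both furan compounds beyond the scatter, so the group at this place can move the result. Nothing in the data shown explains this difference.

Because sulfur and the methyl group enter together, the compounds shown do not separate their contributions. As far as these compounds go, how thiophen-2-yl, 5-methylfuran-2-yl or 5-ethylthiophen-2-yl would read in this assay remains open.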